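Two Inactive Analogues and a Hybrid Built Between Them

The source may hold more compounds than are shown below. What is called first, only, known or untested is meant among the compounds shown, and "the series" means these compounds.

Compound 1 `CC(C)C[C@H](NC(=O)CNC(=O)c1ccn(CC(=O)NOCc2ccccc2)c1)C(=O)O` gives > 128000 nM in a functional assay on MRC5 cells (Homo sapiens) for inhibition, read by microscopy and resazurin assay, with a stated time of 72 h; a higher number here means a weaker inhibitor, a lower number a stronger inhibitor.
Compound 2 `CC(C)[C@H](NC(=O)[C@H](C)NC(=O)c1ccn(CC(=O)NOCc2ccccc2)c1)C(=O)O` gives > 128000 nM in this assay.

Both of these values are limits of the assay and not numbers. Compound 2 therefore stands at the limit of > 128000 nM in this assay, at which 2 of the 2 values shown sit, with no measurable inhibition in this assay, and the same holds for compound 1. Among the compounds with values here, no step between the two can be sized from such limits.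

Compound 3 `CC(C)C[C@H](NC(=O)[C@H](C)NC(=O)c1ccn(CC(=O)NOCc2ccccc2)c1)C(=O)O` has not yet been measured. It differs from compound 2 in a single place: isobutyl in place of isopropyl on a saturated chain carbon bound to an amide-type nitrogen and a carbonyl carbon. Compound 1 already carries this isobutyl group, with a different middle amino acid, and compound 1 also sits at the limit.

With both neighbours at the limit, the step from compound 2 to compound 3 in this assay is expected to be none beyond the scatter, and a step that the limit leaves unreadable from compound 2 to compound 3 is the estimate. Compound 3 is expected to show 200000 nM, within a range from 100000 nM to 500000 nM, most likely again as a limit rather than a number.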

Compound 3, half-maximal inhibitory concentration: > 128000 nM
Compound 3 was reported as a limit; the forecaster's own chance of this, stated with the estimate: 85%; the middle value lies beyond the limit too.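

Within the data shown here, compound 3, like compound 1 and compound 2, sits at a limit of the assay and not at a number, so no step from compound 1 or compound 2 to compound 3 can be read: the limit of > 128000 nM in this assay, at which 3 of the 3 values shown sit. The compounds shown leave open whether these three differ at all in this assay.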